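Methyl to Fluoro Repeated on a Second Core

This account rests on a few compounds, and the source may have more. Where it says the series, first, only, none or still open, it means among the compounds named here.

Three compounds have been measured in a functional assay on HT-29 cells (Homo sapiens) for cytotoxicity, read by MTT assay, with a stated time of 72 h; a lower number here means a stronger inhibitor, a higher number a weaker inhibitor:
Compound 1, `COc1cc2c(Oc3ccc(NC(=O)c4cc(-c5ccc(F)cc5)ccn4)cc3F)ccnc2cc1OCCCN1CCCCC1`, gives 1370 nM.
Compound 2, `COc1cc2c(Oc3ccc(NC(=O)c4cc(-c5ccc(C)cc5)ccn4)cc3F)ccnc2cc1OCCCN1CCCCC1`, gives 340 nM.
Compound 3, `COc1cc2c(Oc3ccc(NC(=O)c4nccc(-c5ccc(C)cc5)n4)cc3F)ccnc2cc1OCCCN1CCCCC1`, gives 620 nM.

Compounds 1 and 2 share one core and differ in a single spot: fluoro in place of methyl on an aromatic carbon. That exchange made the step of a 4.0-fold higher number from compound 2 to compound 1 (0.61 log units; beyond the scatter), so in this assay the fluoro partner came out as the weaker inhibitor of the pair.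

Compound 3 carries the methyl group on a different core; the difference between the two cores is not broken down here. The values of compound 3 and compound 2 lie within the usual scatter of each other, so nothing can be said about which of the two is the stronger.

Compound 4, `COc1cc2c(Oc3ccc(NC(=O)c4nccc(-c5ccc(F)cc5)n4)cc3F)ccnc2cc1OCCCN1CCCCC1`, has not yet been measured. It stands to compound 3 exactly as compound 1 stands to compound 2: fluoro in place of methyl on an aromatic carbon. The place of the exchange reads the same in both pairs, so this is the same change, only made on the core of compound 3.

Among the compounds with values here, for compound 4 a step of about the same size as before is expected, a 3.5-fold higher number from compound 3 to compound 4 (0.55 log units; beyond the scatter), because the one measured example of this exchange gave a 4.0-fold higher number from compound 2 to compound 1 (0.61 log units; beyond the scatter). Since that rests on a single pair on another core, the expectation is held loosely. Compound 4 is estimated at 2200 nM, with a plausible range from 900 nM to 5500 nM.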

Compound 4, half-maximal inhibitory concentration: 120 nM
Beside the measured number, compound 4's estimate is 18-fold (1.26 log units) above it; the whole stated range lies above it.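

In this assay the exchange of methyl for fluoro on the second core gave a 5.2-fold lower number from compound 3 to compound 4 (0.71 log units; beyond the scatter) and so left the fluoro partner as the stronger inhibitor of its pair, the reverse of the result on the first core. The same 4-methylphenyl to 4-fluorophenyl change therefore moved the number in opposite directions, and the gap between the two steps is larger than repeat measurements would explain: the same change on two cores in this assay, a 4.0-fold higher number (0.61 log units; beyond the scatter) from compound 2 to compound 1 and a 5.2-fold lower number (0.71 log units; beyond the scatter) from compound 3 to compound 4, 21-fold (1.32 log units) apart, beyond the scatter of two such steps. Within the data shown here, this shows that the effect of the exchange depends on the core that carries it, so a step measured on one core cannot simply be transferred to another, but with only one pair on each core it does not show why the two cores part ways or what a third core would do.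

The compounds shown carry only methyl or fluoro at this spot, so it remains open how a chloro group, a methoxy group or a plain hydrogen would read on each core. From the compounds shown here alone, it also remains open whether a longer chain such as ethyl in place of methyl would show the same reversal between the two cores.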